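Ring Substituent Changes on a Diacylhydrazine Ecdysone Agonist

A few compounds are considered here, and "the series" means these few. Any claim that something is new, unique, unknown or untested is made for them only; others in the source may bear on it.

Three close relatives share one core and differ only in the aromatic ring attached to one carbonyl carbon. Compound 1 `CC(C)(C)N(NC(=O)c1ccccc1Cl)C(=O)c1ccccc1Cl` gives 331 nM in an assay on cells for agonist activity at ecdysone receptor (Bombyx mori), read by a luciferase reporter, with a stated time of 24 h; a higher number here means that more compound is needed for the effect, a lower number that less compound is needed. Compound 2 `CC(C)(C)N(NC(=O)c1cccc(Br)c1)C(=O)c1ccccc1Cl` gives 191 nM in this assay, and compound 3 `CC(C)(C)N(NC(=O)c1ccc(Cl)cc1)C(=O)c1ccccc1Cl` gives 115 nM. Compound 3 has the lowest of the three numbers; its step of a 2.9-fold lower number from compound 1 to compound 3 (0.46 log units; beyond the scatter) lies beyond the scatter, while its step of a 1.7-fold lower number from compound 2 to compound 3 (0.22 log units; within the scatter) does not, and a 1.7-fold lower number from compound 1 to compound 2 (0.24 log units; within the scatter) is also within the scatter.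

Compound 4 `Cc1cccc(C(=O)NN(C(=O)c2ccccc2Cl)C(C)(C)C)c1C` differs from compound 3 by 2,3-dimethylphenyl in place of 4-chlorophenyl on a carbonyl carbon. The steps already seen only move a halogen around the ring; none replaces a halogen with two methyl groups, so they bear on this change only loosely, suggesting that modest shifts of the ring substituent move the number by small amounts. Compound 4 is therefore expected to land close to compound 3, with a step of a 2.2-fold higher number from compound 3 to compound 4 (0.34 log units; beyond the scatter) that is expected to stay near the scatter. The estimate for compound 4 is 250 nM, within a range from 60 nM to 1000 nM.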

Compound 4, half-maximal effective concentration: 20 nM
Estimate against measurement, compound 4: 13-fold (1.10 log units) above; measured number below the stated range.
By their numbers in this assay, from the lowest: compound 4; then compounds 3, 2 and 1 (each within the scatter of the next, the first and the last beyond it).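

In this assay, this place on the carbonyl carbon proves able to do more than the halogen moves suggested: 2,3-dimethylphenyl gives a 5.8-fold lower number from compound 3 to compound 4 (0.76 log units; beyond the scatter) against 4-chlorophenyl, a 9.6-fold lower number from compound 2 to compound 4 (0.98 log units; beyond the scatter) against 3-bromophenyl and a 17-fold lower number from compound 1 to compound 4 (1.22 log units; beyond the scatter) against 2-chlorophenyl. Within the data shown here, all three steps lie beyond the scatter, so compound 4 stands apart from every other compound here, whereas among the halogen-bearing rings only the step between compound 1 and compound 3 did so. Nothing available here accounts for this gain.

The compounds shown leave open whether both methyl groups are needed or whether a ring with a single methyl group would give a similar number. From the compounds shown here alone, how ethyl groups, methoxy groups or an amine on this ring would compare also remains unknown.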